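Removing the aromatic bromine from the longer-chain analogue

The source may hold more compounds than are shown below. What is called first, only, known or untested is meant among the compounds shown, and "the series" means these compounds.

Compound 1, `O=C(CCCCNC(=O)C(O)(O)C(F)(F)F)Nc1ccccc1`: 20300 nM
Compound 2, `O=C(CCCCCCNC(=O)C(O)(O)C(F)(F)F)Nc1ccc(Br)cc1`: 3130 nM

Both compounds were tested in a functional assay on HCT-116 cells (Homo sapiens) for inhibition, read by colorimetric assay, with a stated time of 3 days; on this read-out lower numbers stand for stronger inhibition and higher numbers for weaker inhibition. Of the two numbers, compound 2 has the lower one; compound 1, its nearest neighbour, gives a number higher by a margin that lies beyond the scatter. The two structures differ in more than one place, so nothing finer than this comparison of the two values can be drawn from them.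

Compound 3, `O=C(CCCCCCNC(=O)C(O)(O)C(F)(F)F)Nc1ccccc1`, is the unmeasured member of the set. It keeps the chain of compound 2 and changes only the aromatic ring: hydrogen in place of bromo on an aromatic carbon. The expected effect on this assay is a modest rise, since compound 2 stands at 3130 nM and the bromine is the one feature of its ring that compound 1 lacks. The step from compound 2 to compound 3 is estimated at a 2.1-fold higher number from compound 2 to compound 3 (0.32 log units; beyond the scatter), a shift that may or may not clear the scatter. Compound 3 is therefore expected to give about 6500 nM, with a plausible range of 2500 nM to 16000 nM.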

Compound 3, half-maximal inhibitory concentration: 9140 nM
The estimate for compound 3 lay 1.4-fold (0.15 log units) below the measured number; low and high end bracket the measured number.
By their numbers in this assay, from the lowest: compound 2; then compound 3; then compound 1.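

In this assay, the bromo group now has a measured contribution of its own: with the chain held as in compound 2, hydrogen in place of bromo on the aromatic carbon gives a 2.9-fold higher number from compound 2 to compound 3 (0.47 log units; beyond the scatter) on this exchange alone, something the earlier pair could not show, since its two members differ in more than one place. This position, para to a large group, is therefore not indifferent to what it carries, at least for this one exchange, and the 4-bromophenyl form gives the lower number of the two. No supporting measurement accounts for the size or direction of this shift.

On these data alone, it remains open whether other groups at this position, such as chloro, methoxy, an amine or a carboxylic acid, would give a lower or a higher number than bromo. The compounds shown also leave open whether a bromo group on the ring of compound 1, with its shorter chain, would produce a step of similar size, and whether a longer chain would change the picture.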